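The compounds below may be only part of what the source reports. "The series", "measured", "known", "first", "only" and "open" are said of these compounds alone.

In an ADME assay on MRC5 cells (Homo sapiens) for cytotoxicity, read by MTT assay, with a stated time of 48 h (a lower number here means a stronger inhibitor, a higher number a weaker inhibitor), compound 1 (`Cc1[nH]c2ccc([N+](=O)[O-])cc2c1C1(c2c(C)[nH]c3ccc([N+](=O)[O-])cc23)C(=O)Nc2ccccc21`) gives > 100000 nM, which is a limit of the assay and not a number. Compound 2 (`O=C1Nc2ccc(Cl)cc2C1(c1c(-c2ccccc2)[nH]c2ccccc12)c1c(-c2ccccc2)[nH]c2ccccc12`) gives > 100000 nM, which is also a limit. Compound 1 therefore stands at the limit of > 100000 nM in this assay, at which 2 of the 2 values shown sit, so there is no exact number to start from. Compound 3 (`Cc1[nH]c2ccc([N+](=O)[O-])cc2c1C1(c2c(C)[nH]c3ccc([N+](=O)[O-])cc23)C(=O)Nc2ccc(Cl)cc21`) keeps the core of compound 1 but has chloro in place of hydrogen on an aromatic carbon. Within the data shown here, no measured pair shows what this change does in this assay. The expectation is therefore for no step beyond the scatter, in either direction, and compound 3 will probably also reach a limit rather than give a number. The expected step is small: a number no higher from compound 1 to compound 3 (the limit leaves the size open). For compound 3, the estimated value is 100000 nM, with an expected range from 35000 nM to 200000 nM.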

Compound 3, half-maximal inhibitory concentration: > 100000 nM
Compound 3: only a limit was reported; the forecaster's own chance of this, stated with the estimate: 70%; the middle value lies on the limit itself.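

Compound 1 and compound 3 both give a limit of the assay rather than a number in this assay, so no step can be read from this pair. The compounds shown leave open whether chloro in place of hydrogen on an aromatic carbon changes the result at all.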